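A few compounds are considered here, and "the series" means these few. Any claim that something is new, unique, unknown or untested is made for them only; others in the source may bear on it.

Measured so far in an ADME assay on cells (Hepatocyte, Mus musculus) for metabolic stability; a lower number here means that the compound disappears faster, a higher number that the compound lasts longer:
- compound 1, `O=C(OC1CCC(CN2CCN(c3cc(=O)c4cc(C(F)(F)F)cc([N+](=O)[O-])c4s3)CC2)CC1)c1ccccc1`: 0.903 h
- compound 2, `O=c1cc(N2CCN(CC3CCC(NS(=O)(=O)c4ccccc4)CC3)CC2)sc2c([N+](=O)[O-])cc(C(F)(F)F)cc12`: a limit, > 1.55 h
- compound 3, `O=C(OC1CCC(CN2CCN(c3cc(=O)c4cc(C(F)(F)F)cc([N+](=O)[O-])c4s3)CC2)CC1)c1ccco1`: a limit, < 0.075 h

Compound 2 sits at the upper edge of the numbers seen here: its value in this assay is a limit and not a number, the line (the limit of > 1.55 h in this assay, at which 1 of the 3 values shown sits). Compound 3 likewise stands at a limit, the line (the limit of < 0.075 h in this assay, at which 1 of the 3 values shown sits). For the measured compounds named here, compound 1 is the only member with a plain number.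

Compound 4, `COc1ccc(C(=O)OC2CCC(CN3CCN(c4cc(=O)c5cc(C(F)(F)F)cc([N+](=O)[O-])c5s4)CC3)CC2)cc1`, is the next step from compound 2. The change is ((4-methoxyphenyl)carbonyl)oxy in place of (phenylsulfonyl)amino on a saturated ring carbon. Going by the values given here, two measured steps bear on it. The step of an at least 1.7-fold higher number from compound 1 to compound 2 (0.23 log units; that floor lies within the scatter) puts benzoyloxy close to (phenylsulfonyl)amino. The step of an at least 20-fold lower number from compound 2 to compound 3 (1.31 log units; beyond the scatter) shows that a furan-2-yl carbonyl on the same position drops the half-life hard. Compound 4 carries an aromatic six-membered ring like compound 1 rather than furan-2-yl, so the nearer reference is compound 1.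

Expected: a modest drop an at least 2.5-fold lower number from compound 2 to compound 4 (0.41 log units; beyond the scatter), landing near compound 1 and well above compound 3. Estimate for compound 4 in this assay: 0.6 h, with a range of 0.15 h to 1.5 h.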

Compound 4, half-life: 0.295 h
Compound 4: middle estimate off by 2.0-fold (0.31 log units), on the high side; low and high end bracket the measured number.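

In this assay, the ester at this saturated ring carbon responds to a small change on its aromatic ring: with methoxy in place of hydrogen, the result is a 3.1-fold lower number from compound 1 to compound 4 (0.49 log units; beyond the scatter), a step beyond the scatter that compounds 1 to 3 could not show. The gap between ((4-methoxyphenyl)carbonyl)oxy and (phenylsulfonyl)amino is also clear, at an at least 5.2-fold lower number from compound 2 to compound 4 (0.72 log units; beyond the scatter), whereas benzoyloxy gave only an at least 1.7-fold higher number from compound 1 to compound 2 (0.23 log units; that floor lies within the scatter), so the (phenylsulfonyl)amino group now stands apart from at least one aromatic ester. The 4-methoxyphenyl ester still keeps its distance from the furan-2-yl ester, at an at least 3.9-fold higher number from compound 3 to compound 4 (0.59 log units; beyond the scatter), but compound 2 and compound 3 each stand at a limit of the assay, so the steps that involve them are bounds and not sizes.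

Nothing shown here gives a measured reason for the lower number with methoxy. Going by these compounds, it remains open whether the drop is specific to methoxy or would also follow from a fluorine or an amine on the same aromatic ring, and whether an amide in place of the ester would move compound 4 towards compound 2.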